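Hydroxylation of the aryloxypropanol chain: lipophilicity notes

The compounds below may be only part of what the source reports. "The series", "measured", "known", "first", "only" and "open" are said of these compounds alone.

Three compounds of the series have been run in a physicochemical assay for lipophilicity, measured as octanol-water partition; a lower number here means a more polar compound, a higher number a more lipophilic compound. Compound 2 `Cc1cccc(Cl)c1OCCCO` gives 2.93. Compound 1 `Cc1cccc(Cl)c1OCC(O)CO` gives 1.97. The structural change between them is hydroxy in place of hydrogen on a saturated chain carbon bound to two saturated chain carbons, and this step a number 0.96 log units lower from compound 2 to compound 1 (beyond the scatter). Compound 3 `CC(O)COc1ccc(Cl)cc1Cl` gives 2.75, which lies within the scatter of the value of compound 2 and beyond the scatter against the value of compound 1. The difference between the cores of compound 2 and compound 3 is not broken down here.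

Compound 4 `OCC(O)COc1ccc(Cl)cc1Cl` remains to be measured. Relative to compound 3 its change is hydroxy in place of hydrogen on a saturated chain carbon, two bonds along the chain from an oxygen on a saturated carbon. Within the data shown here, this is the same kind of change as the one from compound 2 to compound 1, though not the same: there the added hydroxy sat on a saturated chain carbon bound to two saturated chain carbons, whereas here it sits on a saturated chain carbon two bonds along the chain from an oxygen on a saturated carbon. Among the measured compounds shown here, with only one earlier instance of this change, the expectation rests on that single step, a number 0.96 log units lower from compound 2 to compound 1 (beyond the scatter), applied to the value of compound 3, 2.75. The step from compound 3 to compound 4 in this assay is thus expected to be a number 0.95 log units lower from compound 3 to compound 4 (beyond the scatter), with some widening of the range for the different surroundings of the new hydroxy. The estimate for compound 4 in this assay is 1.8, between 1.4 and 2.2.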

Compound 4, partition coefficient: 1.99
Compound 4: the middle estimate sits 0.19 log units below what was measured; measured number inside the range.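

In this assay, hydroxy in place of hydrogen on the chain gives a number 0.76 log units lower from compound 3 to compound 4 (beyond the scatter) on one core and a number 0.96 log units lower from compound 2 to compound 1 (beyond the scatter) on the other, so in both pairs the number falls, beyond the scatter. This shows that the direction of the change held across the two cores shown, but two pairs are too few to establish a general rule for the series, and the pairs differ in both the core and the place of the new hydroxy, so any influence of core on the size of the step cannot be separated from that of place. Nothing on hand gives a reason for the size of either step.

Still open, going by these compounds, is how the step would read with the core held fixed and only the place of the hydroxy moved, and whether it would carry to cores beyond these two. Also open, on these data alone, is whether an amine or a carboxylic acid on a saturated chain carbon, two bonds along the chain from an oxygen on a saturated carbon, would follow the hydroxy steps, and whether a longer chain would keep them.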